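Trifluoromethyl for methyl on the anilino ring of compound 2

The source may report more compounds than this note shows. Statements on the series, on what has been measured and on what is new or still open speak of the compounds shown alone.

Measured so far:
compound 1 `Nc1nccc(-c2ccnc3ccccc23)n1` — 77.4%
compound 2 `Cc1ccc(Nc2nccc(-c3c(C)nc4ccccn34)n2)cc1` — 94.2%
compound 3 `Cc1nc2ccccn2c1-c1ccnc(Nc2ccc(C=O)s2)n1` — 49.5%

Of the three compounds tested in a functional assay on PC-3 cells (Homo sapiens) for cytotoxicity, read by sulforhodamine B assay, with a stated time of 48 h, tested at 50 uM (a lower number here means less inhibition, a higher number more inhibition at the concentration tested (going by the name of the read-out)), compound 2 stands highest, with compound 1 coming nearest and compound 3 furthest away; both of those gaps lie beyond the scatter. For the measured compounds named here, the only single-point step among the measured compounds runs from compound 2 to compound 3, where the change at the nitrogen on the aromatic ring gives a number 44.7 percentage points lower from compound 2 to compound 3 (beyond the scatter), a large fall.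

Compound 4 `Cc1nc2ccccn2c1-c1ccnc(Nc2ccc(C(F)(F)F)cc2)n1` is not yet measured. It differs from compound 2 as follows: trifluoromethyl in place of methyl on an aromatic carbon. The group sits on an aromatic carbon of a six-membered aromatic ring of carbon only, para to a large group.

Going by the values given here, no measured step concerns this particular exchange; the step from compound 2 to compound 3 alters the whole ring that bears the substituent, not the substituent alone, and so bears on it only loosely. With compound 2 already close to the top of what this assay can report, the expected step from compound 2 to compound 4 is estimated at a number 9.2 percentage points lower from compound 2 to compound 4 (within the scatter), a small fall that may well stay within the scatter. Compound 4 is therefore expected to give about 85%, within a range from 60% to 98%.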

Compound 4, a percentage reported as inhibition, at one concentration (the size of the read-out at that concentration, not a potency): 64.5%
Compound 4: the middle estimate sits 20.5 percentage points above what was measured; the measured number falls inside the stated range.
By their numbers in this assay, from the lowest: compound 3; then compound 4; then compound 1; then compound 2.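

In this assay, trifluoromethyl in place of methyl on an aromatic carbon, para to a large group, gives a number 29.7 percentage points lower from compound 2 to compound 4 (beyond the scatter). This shows that the position responds to a change of the substituent alone, with the six-membered aromatic ring left in place, which the earlier step of a number 44.7 percentage points lower from compound 2 to compound 3 (beyond the scatter) could not show, as that step replaced the whole ring bearing the substituent. Nothing available on these groups accounts for the fall seen with trifluoromethyl, so the result stands as an observation without an explanation.

The compounds shown carry only methyl and trifluoromethyl at this place on the ring, so it remains open how an amine, a carboxylic acid, a chlorine atom or a longer alkyl chain there would read in this assay, and whether the number depends on the group's identity in any orderly way. Also open, from the compounds shown here alone, is whether the same exchange would give a similar step on a core other than that of compound 2, since this single step comes from one pair of compounds read at one concentration.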